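A few compounds are considered here, and "the series" means these few. Any claim that something is new, unique, unknown or untested is made for them only; others in the source may bear on it.

Compound 1 `C/N=C(\NC#N)Nc1cccnc1` — in a functional assay on the whole organism (blood, strain Wistar-Okamoto) with Rattus norvegicus as the target, with a stated time of 5 days (on this read-out higher numbers stand for an effect only at larger amounts of compound and lower numbers for an effect already at smaller amounts), compound 1 gives > 50 mg/kg, which is a limit of the assay rather than a number.
Compound 2 `CCC/N=C(\NC#N)Nc1cccnc1` — in this assay compound 2 gives 20 mg/kg.
Compound 3 `CC(C)C/N=C(\NC#N)Nc1cccnc1` — in this assay compound 3 gives 20 mg/kg.

Compound 3 stands level with compound 2 on the numbers shown, with compound 2 its nearest neighbour; the step of no change at the digits printed from compound 2 to compound 3 (within the scatter) lies within the scatter, so no order can be read between the two. Compound 1 sits at the limit of > 50 mg/kg in this assay, at which 1 of the 3 values shown sits, and the steps of an at least 2.5-fold lower number from compound 1 to compound 2 (0.39 log units; beyond the scatter) and an at least 2.5-fold lower number from compound 1 to compound 3 (0.39 log units; beyond the scatter) show that a chain on that carbon, whether ethyl or isopropyl, moves the dose downward beyond the scatter.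

Compound 4 `CC(C)/N=C(\NC#N)Nc1cccnc1` is the next compound. Its change from compound 3 is isopropyl in place of isobutyl on a double-bonded nitrogen. Here the chain that leaves is isobutyl and the chain that enters is isopropyl, so the group on the double-bonded nitrogen becomes shorter but stays branched. The step that bears most on this is no change at the digits printed from compound 2 to compound 3 (within the scatter), where adding a methyl to the chain changed nothing beyond the scatter; the steps from compound 1 show only that some chain is needed, which compound 4 keeps. A step of no change at the digits printed from compound 3 to compound 4 (within the scatter) is therefore expected, that is, none beyond the scatter. Compound 4 is estimated at 20 mg/kg, between 10 mg/kg and 40 mg/kg.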

Compound 4, minimum effective dose: 2.5 mg/kg
Beside the measured number, compound 4's estimate is 8.0-fold (0.90 log units) above it; the measured number lies below the stated range.
By their numbers in this assay, from the lowest: compound 4; then compounds 2 and 3 (each within the scatter of the next). At a limit, above all of these: compound 1.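

The earlier compounds shown here suggested that any chain on the double-bonded nitrogen would do, since propyl and isobutyl could not be told apart, but in this assay isopropyl separates from both (an 8.0-fold lower number from compound 3 to compound 4 (0.90 log units; beyond the scatter); an 8.0-fold lower number from compound 2 to compound 4 (0.90 log units; beyond the scatter)). So the exact identity of the chain matters at this position, and the order does not simply follow chain length: isopropyl gives a lower number than propyl and isobutyl, yet methyl, the other group here that is shorter than both, does not. Going by these compounds, the step from methyl to isopropyl (an at least 20-fold lower number from compound 1 to compound 4 (1.30 log units; beyond the scatter)) is the largest seen so far, and its true size is unknown, as compound 1 is recorded only at a limit of the assay: (the limit of > 50 mg/kg in this assay, at which 1 of the 4 values shown sits).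

The compounds shown leave open whether the gain belongs to isopropyl alone or extends to other compact groups on the same nitrogen, such as tert-butyl, cyclopropyl or cyclobutyl. They also leave open how a longer chain such as pentyl would behave, and whether changes to the shared core would keep the order seen among these chains.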